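Trimming the sulfonyl substituent of a potent phenoxyacetic acid

A few compounds are considered here, and "the series" means these few. Any claim that something is new, unique, unknown or untested is made for them only; others in the source may bear on it.

For the measured compounds named here, compound 1 `COCCN(C)S(=O)(=O)c1ccc(C)c(C#Cc2cc(Cl)ccc2OCC(=O)O)c1` is one of two compounds measured in an assay on CHO cells for displacement of a labelled ligand from prostaglandin D2 receptor 2 (Homo sapiens), read by scintillation counting (on this read-out higher numbers stand for weaker inhibition and lower numbers for stronger inhibition), where compound 1 gives 4.1 nM. This is the lower of the two numbers, and the gap to its neighbour is wide: compound 2 `O=C(O)COc1cc(F)ccc1C#Cc1ccccc1Cl`, which lacks the sulfonyl group altogether and carries a different halogen pattern, gives 4780 nM in this assay, a difference far beyond the usual scatter. Between compounds 1 and 2 no single-point step exists, so their two values can only be set side by side.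

Compound 3 `Cc1ccc(S(C)(=O)=O)cc1C#Cc1cc(Cl)ccc1OCC(=O)O` keeps the whole core of compound 1 and alters only the group on the sulfonyl sulfur: methyl in place of (2-methoxyethyl)(methyl)amino on a sulfonyl sulfur. A six-atom chain gives way to a single carbon, so the molecule becomes smaller at that end.

Going by the values given here, no measured pair shows what such a change does. Because compound 1 gives 4.1 nM, the starting point is strong, and only a modest weakening is expected for compound 3, a step of a 2.9-fold higher number from compound 1 to compound 3 (0.47 log units; beyond the scatter). Compound 3 is therefore estimated at 12 nM, with a range from 3 nM to 50 nM.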

Compound 3, inhibition constant: 5 nM
Beside the measured number, compound 3's estimate is 2.4-fold (0.38 log units) above it; low and high end bracket the measured number.
By their numbers in this assay, from the lowest: compounds 1 and 3 (each within the scatter of the next); then compound 2.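

In this assay, putting methyl in place of (2-methoxyethyl)(methyl)amino on a sulfonyl sulfur gives a 1.2-fold higher number from compound 1 to compound 3 (0.09 log units; within the scatter), so compound 1 and compound 3 cannot be told apart on this read-out. For the compounds shown here, compound 2 could not show this, as it has no sulfonyl group and also differs from compound 1 in other places; this pair is the first to isolate the group on the sulfur, and it shows that, on the core of compound 1, the full chain of the sulfamoyl group is not required for a low number, as a single methyl reads alike. Nothing measured here accounts for why the two compounds read alike.

The compounds shown leave open how far this freedom at the sulfur extends: an ethyl group, a plain amine or a morpholine ring in the same place could read alike or could read quite differently. Going by these compounds alone, they also leave open what the sulfonyl group itself contributes, since no compound with the core of compound 1 carries a hydrogen or a nitrile in its place.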